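The source may hold more compounds than are shown below. What is called first, only, known or untested is meant among the compounds shown, and "the series" means these compounds.

Working notes on the series. Compound 1 `COc1ccc(-n2cc(COc3ccc(/C=N/Nc4nc(-c5ccc(Br)cc5)cs4)cc3)nn2)cc1` and compound 2 `COc1ccc(-c2csc(N/N=C/c3ccc(OCc4cn(-c5ccc(OC)cc5)nn4)cc3)n2)cc1` share one core and differ only in the substituent on the pendant phenyl ring. In an ADME assay on THP-1 cells (Homo sapiens) for cytotoxicity (on this read-out higher numbers stand for lower toxicity in this test and lower numbers for higher toxicity in this test), compound 1 gives 35600 nM, and in this assay compound 2 gives 39000 nM. Going by the values given here, the step of a 1.1-fold higher number from compound 1 to compound 2 (0.04 log units; within the scatter) is within the scatter, so compound 1 stands level with compound 2 on the two numbers measured so far; neither can be set apart from the other.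

Compound 3 `COc1ccc(-n2cc(COc3ccc(/C=N/Nc4nc(-c5cc6ccccc6oc5=O)cs4)cc3)nn2)cc1` is not yet measured. It differs from compound 1 as follows: a group of 11 heavy atoms (9 carbon, 2 oxygen; one six-membered aromatic ring of carbon only, one six-membered aromatic ring with 1 hetero atom) in place of a group of 7 heavy atoms (6 carbon, 1 bromine; one six-membered aromatic ring of carbon only), on an aromatic carbon. Among the compounds with values here, the only measured step that bears on this position is a 1.1-fold higher number from compound 1 to compound 2 (0.04 log units; within the scatter), which exchanged one substituent on the same 4-bromophenyl group and stayed within the scatter. Within the data shown here, that step is a narrower change than the one to compound 3, and there is no measured step in which the whole group is replaced. For compound 3 no step beyond the scatter is expected in this assay, so the estimated step is a 1.0-fold lower number from compound 1 to compound 3 (0.01 log units; within the scatter). Compound 3 is expected to give 35000 nM, in the range 12000 nM to 100000 nM.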

Compound 3, half-maximal cytotoxic concentration: 36300 nM
Estimate against measurement, compound 3: 1.0-fold (0.02 log units) below, and the stated range covers the measured number.
By their numbers in this assay, from the lowest: compounds 1, 3 and 2 (each within the scatter of the next).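

In this assay, the group of 11 heavy atoms, with its second six-membered aromatic ring and 2 hydrogen-bond acceptors, replaces 4-bromophenyl with a 1.0-fold higher number from compound 1 to compound 3 (0.01 log units; within the scatter), and it replaces the methoxy-bearing group with a 1.1-fold lower number from compound 2 to compound 3 (0.03 log units; within the scatter). Going by these compounds alone, the position on an aromatic carbon of the five-membered aromatic ring with 1 nitrogen and 1 sulfur therefore stays within the scatter even when the whole group is exchanged and its size and ring count change, whereas the earlier compounds covered only a substituent swap on one phenyl ring. Nothing at hand accounts for this flat result.

From the compounds shown here alone, all three groups at this position are built on an aromatic ring of carbon, so it remains open whether an amine, a carboxylic acid or a simple longer alkyl chain placed there would give a number beyond the scatter. The three compounds also share the rest of the core, which leaves open how far the read-out responds to a change anywhere else in the molecule.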